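Trading a Five-Membered Oxygen Ring for Its Sulfur Counterpart

The compounds below may be only part of what the source reports. "The series", "measured", "known", "first", "only" and "open" are said of these compounds alone.

In a functional assay, read by Griess assay, with a stated time of 150 min, tested at 100 ug/mL (a lower number here means a weaker effect, a higher number a stronger effect of the compound at the concentration tested), compound 2 `COc1ccc(C2=NN(c3ccccc3)C(c3ccc(C)cc3)C2S(=O)(=O)CC2=NCCO2)cc1` gives 70.5%. Among the compounds examined it stands as the only one with a reported number. Compound 1 `O=S(=O)(CC1=NCCO1)c1c(-c2ccc(Cl)cc2)nn(-c2ccccc2)c1-c1ccc(Cl)cc1` is reported as "not active" (no number reported) in this assay, and compound 3 `O=S(=O)(CC1=NCCS1)C1C(c2ccccc2)=NOC1c1ccccc1` is likewise reported as "not active" (no number reported), so neither offers a figure that can be set against compound 2. Going by the values given here, no pair of measured compounds differs in just one place, and so no measured step is available to guide an expectation.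

Compound 4 `COc1ccc(C2=NN(c3ccccc3)C(c3ccc(C)cc3)C2S(=O)(=O)CC2=NCCS2)cc1` has not yet been tested. It differs from compound 2 by a group of 5 heavy atoms (3 carbon, 1 nitrogen, 1 sulfur; one five-membered non-aromatic ring with 2 hetero atoms) in place of a group of 5 heavy atoms (3 carbon, 1 nitrogen, 1 oxygen; one five-membered non-aromatic ring with 2 hetero atoms), on a saturated chain carbon bound to a sulfonyl sulfur. Among the compounds with values here, compound 3 carries the same sulfur-containing five-membered ring on a different core and is reported as "not active" (no number reported), but the core is not the one shared by compound 2 and compound 4, so that result says little about the present change. In the absence of a measured step, the expected step of a number 10.5 percentage points lower from compound 2 to compound 4 (beyond the scatter) is a small loss that may well fall within the ordinary scatter of this assay. The estimate for compound 4 is 60%, with a range expected from 35% to 80%.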

Compound 4, a percentage reported as activity, at one concentration (the size of the read-out at that concentration, not a potency): 50.7%
For compound 4 the middle estimate is 9.3 percentage points above the measured one; the range from low to high includes it.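

Going by these compounds alone, replacing the oxygen-containing five-membered ring with its sulfur counterpart, on a saturated chain carbon bound to a sulfonyl sulfur, gives the first measured step in this set: in this assay, it is a number 19.8 percentage points lower from compound 2 to compound 4 (beyond the scatter). Within the data shown here, this shows that the read-out responds to this single ring-atom exchange on the shared core, yet the exchange does not abolish it, since compound 4 still gives 50.7%; the earlier compounds, with no pair differing in one place, could show neither point. No accompanying measurement bears on why the sulfur ring gives the lower read-out.

The compounds shown leave open how far this step carries over to other cores, since a single pair gives no way of telling whether the same exchange would lower the read-out elsewhere. They also leave open how the read-out would respond if a six-membered ring containing oxygen and nitrogen, an open-chain amine or a carboxylic acid took the place of the five-membered ring on that same saturated chain carbon.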